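The source may report more compounds than this note shows. Statements on the series, on what has been measured and on what is new or still open speak of the compounds shown alone.

Compound 1, `O=C1O/C(=C\Cn2cc(-c3cc(F)cc(F)c3)nn2)C(OCc2ccccc2)=C1OCc1ccccc1`: in a functional assay on HepG2 cells (Homo sapiens) for antiproliferative activity, read by MTT assay, with a stated time of 72 h (on this read-out lower numbers stand for stronger inhibition and higher numbers for weaker inhibition), compound 1 gives > 100000 nM, which is a limit of the assay and not a number.
Compound 2, `CCCCCc1ccc(-c2cn(C[C@H](O)[C@H]3OC(=O)C(OCc4ccccc4)=C3OCc3ccccc3)nn2)cc1`: in this assay compound 2 gives 7460 nM.
Compound 3, `O=C1O/C(=C\Cn2cc(-c3cccc(O)c3)nn2)C(OCc2ccccc2)=C1OCc1ccccc1`: in this assay compound 3 gives 61700 nM.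

Among the compounds with values here, compound 2 holds the lowest of the two numbers measured so far; compound 3 sits a clear distance above it, and compound 1 contributes only a limit (the limit of > 100000 nM in this assay, at which 1 of the 3 values shown sits). Within the data shown here, the single counted step, an at least 1.6-fold lower number from compound 1 to compound 3 (0.20 log units; that floor lies within the scatter), concerns the substituents on an aryl ring and stays within the scatter at its floor.

Compound 4, `Cc1ccc(S(=O)(=O)NCc2cn(C[C@H](O)[C@H]3OC(=O)C(OCc4ccccc4)=C3OCc3ccccc3)nn2)cc1`, has not yet been measured. It differs from compound 2 in one place: (((4-methylphenyl)sulfonyl)amino)methyl in place of 4-pentylphenyl on an aromatic carbon. Among the measured compounds shown here, no measured step touches this kind of exchange; the step from compound 1 to compound 3 alters only the pattern on an aryl ring that compound 4 no longer carries, and compounds 1 and 3 also differ from compound 2 elsewhere in the shared core. The expectation therefore rests on compound 2 alone, as the best number seen, and on the loss of its 4-pentylphenyl group. Compound 4 is expected to give a weaker result, with a 4.0-fold higher number from compound 2 to compound 4 (0.60 log units; beyond the scatter) as the estimated step. Compound 4 is estimated at 30000 nM, within a range from 7000 nM to 100000 nM.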

Compound 4, half-maximal inhibitory concentration: 24900 nM
Beside the measured number, compound 4's estimate is 1.2-fold (0.08 log units) above it; the range from low to high includes it.
By their numbers in this assay, from the lowest: compound 2; then compound 4; then compound 3. At a limit, above all of these: compound 1.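

At the aromatic carbon of the five-membered aromatic ring with 3 nitrogen, putting (((4-methylphenyl)sulfonyl)amino)methyl in place of 4-pentylphenyl gives, in this assay, a 3.3-fold higher number from compound 2 to compound 4 (0.52 log units; beyond the scatter) and this is the first step at this position on this core, and the first step shown that clearly lies beyond the scatter. Both groups carry one six-membered aromatic ring of carbon only, but the entering group gives up the pentyl chain and brings in nitrogen, oxygen and sulfur, with a hydrogen-bond donor and hydrogen-bond acceptors, and the position accepts this broad exchange at a modest cost, with a number rather than a limit for compound 4. Several features change together in this one step, so it cannot be assigned to any single one of them, and nothing measured here bears on its cause.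

Open remains how much of the step belongs to the pentyl chain and how much to the sulfonyl amino link, a question that an unsubstituted phenyl or a longer chain at this carbon would address. Also open is how a simple amine or a carboxylic acid at the same carbon would compare with the two groups shown.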